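The compounds below may be only part of what the source reports. "The series", "measured", "known", "first", "only" and "open" are said of these compounds alone.

Of the compounds shown here, three that share a core have been tested in a functional assay on HBL-100 cells (Homo sapiens) for antiproliferative activity, read by MTT assay, with a stated time of 72 h; on this read-out lower numbers stand for stronger inhibition and higher numbers for weaker inhibition. Compound 1 `Cc1ccc(/C=N/NC(=S)N2CCNCC2)cc1` gives 800 nM in this assay, the second highest of the three numbers. Compound 2 `C/C(=N\NC(=S)N1CCNCC1)c1cccc([N+](=O)[O-])c1` gives 990 nM, and compound 3 `C/C(=N\NC(=S)N1CCNCC1)c1ccc(O)cc1` gives 540 nM; both lie within the usual scatter of the value of compound 1, so the three cannot be told apart on these numbers. Compound 4 `S=C(N/N=C/c1ccc(Cl)cc1)N1CCNCC1` is not yet measured. It differs from compound 1 by chloro in place of methyl on an aromatic carbon, a chloro in place of methyl on an aromatic carbon. Within the data shown here, no comparable step among the measured compounds exists to go by, so no change beyond the scatter is expected; the expected step is no change at the digits printed from compound 1 to compound 4 (within the scatter). Compound 4 is therefore estimated at 800 nM in this assay, within a range from 400 nM to 1600 nM.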

Compound 4, half-maximal inhibitory concentration: 1600 nM
Compound 4: middle estimate off by 2.0-fold (0.30 log units), on the low side; low and high end bracket the measured number.
By their numbers in this assay, from the lowest: compounds 3, 1, 2 and 4 (each within the scatter of the next, the first and the last beyond it).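

In this assay, among these compounds, the first comparison that differs in only one place gives a 2.0-fold higher number from compound 1 to compound 4 (0.30 log units; within the scatter), with chloro in place of methyl on an aromatic carbon, para to a large group. At this position, then, exchanging these two single-atom groups leaves the number within the usual scatter. No measurement shown gives a reason for the size of this step.

Going by these compounds, whether an amine or a carboxylic acid at this position would move the number beyond the scatter remains open. So does whether the same exchange would behave alike on the other compounds in the series.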